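The source may hold more compounds than are shown below. What is called first, only, known or untested is meant among the compounds shown, and "the series" means these compounds.

Compound 1, `CC(C)[C@H](C(=O)NC(C)(C)C)c1ccc(Cl)cc1`: in a functional assay on CHO cells for agonist activity at Free fatty acid receptor 2 (Homo sapiens), read by cAMP accumulation (on this read-out lower numbers stand for stronger inhibition and higher numbers for weaker inhibition), compound 1 reaches only a limit, > 100000 nM.
Compound 2, `CC(C)[C@H](C(=O)Nc1cnns1)c1ccc(Cl)cc1`: in this assay compound 2 gives 57000 nM.

Among the measured compounds shown here, compound 2 holds the only number obtained in this assay; the other entry, that of compound 1, is a limit, namely (the limit of > 100000 nM in this assay, at which 1 of the 2 values shown sits). Compound 3, `Cc1csc(NC(=O)[C@H](c2ccc(Cl)cc2)C(C)C)n1`, differs from compound 2 in one place: 4-methyl-1,3-thiazol-2-yl in place of 1,2,3-thiadiazol-5-yl on an amide-type nitrogen. For the measured compounds named here, only one measured step bears on this position, an at least 1.7-fold lower number from compound 1 to compound 2 (0.24 log units; that floor lies within the scatter), which also exchanges the group on the amide-type nitrogen; its floor lies within the scatter, so it shows that an aromatic group there is not worse than tert-butyl and may be better, without giving a firm size. Nothing measured compares the two five-membered aromatic rings themselves. Compound 3 is therefore expected to sit in the same broad region as compound 2, with a modest shift toward a lower number judged plausible, giving an estimated step of a 2.9-fold lower number from compound 2 to compound 3 (0.45 log units; beyond the scatter). Compound 3 is estimated at 20000 nM, in a range from 4000 nM to 100000 nM.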

Compound 3, half-maximal inhibitory concentration: 1400 nM
For compound 3 the middle estimate is 14-fold (1.15 log units) above the measured one; the whole stated range lies above it.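

The ring on the amide-type nitrogen matters far more in this assay than the earlier comparison could show: the exchange of one five-membered aromatic ring for another gives a 41-fold lower number from compound 2 to compound 3 (1.61 log units; beyond the scatter), so at this position these two rings are not interchangeable. Against tert-butyl, the effect of an aromatic group now has a size beyond the scatter, with an at least 71-fold lower number from compound 1 to compound 3 (1.85 log units; beyond the scatter). That size is only a floor, as compound 1 stands at a limit: the limit of > 100000 nM in this assay, at which 1 of the 3 values shown sits.

The compounds shown leave open whether the step comes from the ring itself or from its methyl group, as the two enter together, which an unsubstituted 1,3-thiazol-2-yl group would separate. Also open, going by these compounds, is how a six-membered pyridin-2-yl ring or a 4-ethyl-1,3-thiazol-2-yl group would read on this nitrogen.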